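This account rests on a few compounds, and the source may have more. Where it says the series, first, only, none or still open, it means among the compounds named here.

Measured so far:
- compound 1 `O=C(Nc1cccc(-n2cc(-c3ccncc3)c(-c3cc(O)cc(Cl)c3)n2)c1)Nc1ccc(Cl)c(Cl)c1` — -58%
- compound 2 `COc1cc(Cl)cc(-c2nn(-c3cccc(NC(=O)Nc4ccc(Cl)c(C(F)(F)F)c4)c3)cc2-c2ccncc2)c1` — -82%
- compound 3 `COc1cc(Cl)cc(-c2nn(-c3cccc(NC(=O)Nc4ccc(Cl)c(Cl)c4)c3)cc2-c2ccncc2)c1` — -21%

All three numbers come from a functional assay on SF-295 cells (Homo sapiens) for inhibition, read by sulforhodamine B assay, with a stated time of 48 h, tested at 100 uM; a lower number here means a stronger effect, a higher number a weaker effect of the compound at the concentration tested. Compound 3 gives the highest number of the set, so the weakest effect shown: the step of a number 37 percentage points higher from compound 1 to compound 3 (beyond the scatter) and the step of a number 61 percentage points higher from compound 2 to compound 3 (beyond the scatter) both raise the number beyond the scatter, the second markedly so.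

Compound 4 `COc1cc(Cl)cc(-c2nn(-c3cccc(NC(=O)c4cccc(C(F)(F)F)c4)c3)cc2-c2ccncc2)c1` is the next compound in the series and has not yet been measured in this assay. The change from compound 3 is 3-(trifluoromethyl)phenyl in place of (3,4-dichlorophenyl)amino on a carbonyl carbon.

Among the measured compounds shown here, two measured steps bear on this, but only loosely. The step of a number 61 percentage points higher from compound 2 to compound 3 (beyond the scatter) shows that, on the terminal ring, a trifluoromethyl in place of a chloro went with a much lower number; compound 4 brings a trifluoromethyl in, although at a different position and with the amino link removed. The step of a number 37 percentage points higher from compound 1 to compound 3 (beyond the scatter) concerns the other end of the molecule and does not speak to this change. For the measured compounds named here, no measured pair covers the loss of the amino link itself.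

The expectation is therefore a moderate step downward, expressed by a number 19 percentage points lower from compound 3 to compound 4 (beyond the scatter), with wide uncertainty. Compound 4 is estimated at -40%, within -90% to 10%.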

Compound 4, a percentage reported as activity, at one concentration (the size of the read-out at that concentration, not a potency): 35%
Estimate against measurement, compound 4: 75 percentage points below; the measured number lies above the stated range.
By their numbers in this assay, from the lowest: compound 2; then compound 1; then compound 3; then compound 4.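

In this assay, compound 4 gives 35%, a positive number where compound 1, compound 2 and compound 3 all give negative ones, and the change at this carbonyl carbon produces a number 56 percentage points higher from compound 3 to compound 4 (beyond the scatter). Starting from (4-chloro-3-(trifluoromethyl)phenyl)amino, the same kind of replacement produces a number 117 percentage points higher from compound 2 to compound 4 (beyond the scatter), so a trifluoromethyl on the terminal ring does not go with a lower number once the amino link is gone, unlike in the earlier pair of compound 2 and compound 3. No measurement shown here explains the shift.

The change removes the amino link and alters the terminal ring substituents in one step, so the compounds shown cannot separate the contribution of the link from that of the ring pattern; a 3,4-dichlorophenyl placed directly on the carbonyl carbon, or a methylamino link carrying the 3-(trifluoromethyl)phenyl, would address that. Also open, on these data alone, is whether the methoxy-to-hydroxy step seen with the amino link, a number 37 percentage points higher from compound 1 to compound 3 (beyond the scatter), holds without it, and all these read-outs come from a single concentration, so they say nothing about potency.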